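A few compounds are considered here, and "the series" means these few. Any claim that something is new, unique, unknown or untested is made for them only; others in the source may bear on it.

Measured compounds:
Compound 1, `NS(=O)(=O)c1ccc(N2N=C(c3ccc(OCc4ccccc4)cc3)CC2c2ccc(F)cc2)cc1`: 60000 nM
Compound 2, `Cc1ccc(C2CC(c3ccc(OCc4ccccc4)cc3)=NN2c2ccc(S(N)(=O)=O)cc2)cc1`: 32000 nM
Compound 3, `Cc1ccccc1C1CC(c2ccc(Oc3ccccc3)cc2)=NN1c1ccc(S(N)(=O)=O)cc1`: 7000 nM

These three compounds were tested in an ADME assay on BHK-21 cells (Mesocricetus auratus) for cytotoxicity, read by MTT assay, with a stated time of 72 h; a higher number here means that more compound is tolerated, a lower number that less compound is tolerated. Compound 2 and compound 1 differ by fluoro in place of methyl on an aromatic carbon, and in this assay that move gives a 1.9-fold higher number from compound 2 to compound 1 (0.27 log units; within the scatter). Compound 3 gives the lowest of the three numbers in this assay; the difference between its core and the core of compound 2 is not broken down here.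

Compound 4, `NS(=O)(=O)c1ccc(N2N=C(c3ccc(Oc4ccccc4)cc3)CC2c2ccccc2F)cc1`, has not yet been measured. It differs from compound 3 by fluoro in place of methyl on an aromatic carbon. Going by the values given here, this is the same kind of change as the one from compound 2 to compound 1, though not the same: there the fluoro stands para to a large group, here it stands ortho to a large group. Because the measured step of a 1.9-fold higher number from compound 2 to compound 1 (0.27 log units; within the scatter) lies within the scatter, only a small step is expected here as well, estimated as a 1.4-fold higher number from compound 3 to compound 4 (0.15 log units; within the scatter). Compound 4 is therefore estimated at 10000 nM in this assay, with a range from 4000 nM to 25000 nM.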

Compound 4, half-maximal cytotoxic concentration: 32000 nM
Compound 4: the middle estimate sits 3.2-fold (0.51 log units) below what was measured; measured number above the stated range.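

In this assay, 2-fluorophenyl in place of 2-methylphenyl gives a 4.6-fold higher number from compound 3 to compound 4 (0.66 log units; beyond the scatter). Set beside the earlier case, the same change does not differ measurably between the two cores: the same change on two cores in this assay, a 1.9-fold higher number (0.27 log units; within the scatter) from compound 2 to compound 1 and a 4.6-fold higher number (0.66 log units; beyond the scatter) from compound 3 to compound 4, 2.4-fold (0.39 log units) apart, within the scatter of two such steps. Going by these compounds alone, this gives no sign that the core alters what the change does, but it does not establish a step of fixed size that can be carried from one core to another: only two pairs stand here, they differ in where the fluoro stands, and only the step on the second core lies beyond the scatter.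

The compounds shown leave open how a chloro, methoxy or trifluoromethyl group in the same place would read in this assay, as fluoro and methyl are the only two groups compared there. They also leave open whether the result would hold on a core carrying a carboxylic acid in place of the sulfonamide.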